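The source may hold more compounds than are shown below. What is called first, only, known or untested is meant among the compounds shown, and "the series" means these compounds.

Compound 1 `Oc1ccc(CNc2cc(C(F)(F)F)cc3[nH]ncc23)cc1` is tested in an assay for inhibition of Tryptophan 2,3-dioxygenase (Homo sapiens), with stated times of 10 min and 60 min, tested at 100 uM (on this read-out lower numbers stand for a weaker effect and higher numbers for a stronger effect at the one concentration tested), and gives 91%, the second highest of the three numbers recorded. Compound 2 `Oc1ccc(CNc2cc(C(F)(F)F)cc3[nH]ncc23)c(Cl)c1` gives 97%, a step of a number 6 percentage points higher from compound 1 to compound 2 (within the scatter) that comes from chloro in place of hydrogen on an aromatic carbon. Compound 3 `NCCn1ncc2c(NCc3ccccc3[N+](=O)[O-])cc(C(F)(F)F)cc21` gives 29%, a much lower number, but it differs from compound 1 in several places at once.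

Compound 4 `FC(F)(F)c1cc(NC[C@H]2CCCCN2)c2cn[nH]c2c1` has not yet been measured. It differs from compound 1 by piperidin-2-yl in place of 4-hydroxyphenyl on a saturated chain carbon bound to a nitrogen on an aromatic ring. Going by the values given here, no measured step touches this part of the molecule, so the one step available, from compound 1 to compound 2, gives no guide. A loss beyond the scatter is expected, of about a number 31 percentage points lower from compound 1 to compound 4 (beyond the scatter). Compound 4 is therefore estimated at 60%, between 25% and 90%.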

Compound 4, a percentage reported as inhibition, at one concentration (the size of the read-out at that concentration, not a potency): 90%
Compound 4: middle estimate off by 30 percentage points, on the low side; low and high end bracket the measured number.
By their numbers in this assay, from the lowest: compound 3; then compounds 4, 1 and 2 (each within the scatter of the next).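

In this assay, piperidin-2-yl in place of 4-hydroxyphenyl on a saturated chain carbon bound to a nitrogen on an aromatic ring gives a number 1 percentage points lower from compound 1 to compound 4 (within the scatter). For this pair, then, the six-membered aromatic ring of carbon only is not needed at this position to hold the read-out, and a non-aromatic ring with a hetero atom serves there as well. No evidence available here accounts for this result.

From the compounds shown here alone, whether the mirror-image piperidin-2-yl, an open-chain amine or a carboxylic acid would hold the number at this position remains open. The single tested concentration also leaves open how compound 1 and compound 4 compare in potency.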